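Methoxy to cyano on the benzyl arm of compound 2

The source may report more compounds than this note shows. Statements on the series, on what has been measured and on what is new or still open speak of the compounds shown alone.

Two compounds of the series have numbers in a functional assay (B cells) with Mus musculus as the target; on this read-out lower numbers stand for an effect already at smaller amounts and higher numbers for an effect only at larger amounts of compound. Compound 1 `C=CCn1c(=S)n(C2OC(CO)[C@@H](O)C(O)[C@H]2O)c2nc(N)nc(O)c21` gives 1 uM. Compound 2 `COc1ccc(Cn2c(=O)n(C3OC(CO)[C@@H](O)[C@H]3O)c3nc(N)nc(O)c32)cc1` gives 135 uM, the higher of the two numbers; the gap to compound 1 is beyond the scatter. Among the measured compounds shown here, compound 1 and compound 2 differ in more than one place, so no single step between measured compounds exists, and only the two values themselves can be compared.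

Compound 3 `N#Cc1ccc(Cn2c(=O)n(C3OC(CO)[C@@H](O)[C@H]3O)c3nc(N)nc(O)c32)cc1` differs from compound 2 by cyano in place of methoxy on an aromatic carbon, that is 4-methoxybenzyl to 4-cyanobenzyl. Nothing in the measured pair speaks to this exchange, and the weight of the exchanged groups is alike. The step from compound 2 to compound 3 is therefore expected to be small, without a clear direction, a 1.4-fold lower number from compound 2 to compound 3 (0.13 log units; within the scatter). In this assay compound 3 is estimated at 100 uM, within 25 uM to 400 uM.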

Compound 3, concentration for half-maximal effect: 15 uM
Beside the measured number, compound 3's estimate is 6.7-fold (0.82 log units) above it, and the stated range ends above it.
By their numbers in this assay, from the lowest: compound 1; then compound 3; then compound 2.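

In this assay, among the compounds shown here, the exchange of 4-methoxybenzyl for 4-cyanobenzyl gives a 9.0-fold lower number from compound 2 to compound 3 (0.95 log units; beyond the scatter) and thereby provides the first single-place step. This aromatic carbon, para to a large group, is therefore not indifferent to what it carries, even though methoxy and cyano match in the heavy-atom and hydrogen-bond-acceptor counts. No measurement on these compounds accounts for the size or direction of the step.

A single exchange cannot show which feature of cyano matters, or whether another group on this carbon, such as an amine, a carboxylic acid or a fluorine atom, would lower the number further or raise it. Also open, on these data alone, is whether moving cyano to another carbon of the ring, or replacing the benzyl arm with a longer chain, would retain the step.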